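The source may hold more compounds than are shown below. What is called first, only, known or untested is meant among the compounds shown, and "the series" means these compounds.

Series in an assay on CHO cells for binding affinity to 5-hydroxytryptamine receptor 1B (Homo sapiens); a higher number here means a weaker inhibitor, a lower number a stronger inhibitor: compound 1 `COC[C@H](NC1CCN(CCCc2c[nH]c3ccc(-n4cnnc4)cc23)CC1)c1ccccc1` gives 210 nM, compound 2 `NC(=O)OC[C@H](NC1CCN(CCCc2c[nH]c3ccc(-n4cnnc4)cc23)CC1)c1ccccc1` gives 120 nM, and compound 3 `C[C@H](NC1CCN(CCCc2c[nH]c3ccc(-n4cnnc4)cc23)CC1)c1ccccc1` gives 95 nM. Compound 3 holds the lowest number of the three, though a 1.3-fold lower number from compound 2 to compound 3 (0.10 log units; within the scatter) is within the scatter; a 2.2-fold lower number from compound 1 to compound 3 (0.34 log units; beyond the scatter) is modest, and a 1.8-fold lower number from compound 1 to compound 2 (0.24 log units; within the scatter) is within the scatter. Compound 4 `CC(=O)Nc1ccc([C@@H](C)NC2CCN(CCCc3c[nH]c4ccc(-n5cnnc5)cc34)CC2)cc1` differs from compound 3 by 1-(4-acetamidophenyl)ethyl in place of 1-phenylethyl on an amine nitrogen. Going by the values given here, none of the measured steps touches the aromatic ring; all three concern the group on the saturated chain carbon, so no measured step bears on this change directly. Among the compounds with values here, with no comparable step available, no shift beyond the scatter is expected, but the uncertainty is wide. Compound 4 is therefore estimated at 95 nM in this assay, range 30 nM to 300 nM, which means an expected no change at the digits printed from compound 3 to compound 4 (within the scatter).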

Compound 4, half-maximal inhibitory concentration: 350 nM
Estimate against measurement, compound 4: 3.7-fold (0.57 log units) below, outside the stated range (above it).
By their numbers in this assay, from the lowest: compounds 3, 2, 1 and 4 (each within the scatter of the next, the first and the last beyond it).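

In this assay, 1-(4-acetamidophenyl)ethyl in place of 1-phenylethyl on the amine nitrogen shows that this position responds to a change on the aromatic ring, not only on the saturated chain carbon, with a 3.7-fold higher number from compound 3 to compound 4 (0.57 log units; beyond the scatter). The gap to the carbamate is similar in kind, with a 2.9-fold higher number from compound 2 to compound 4 (0.46 log units; beyond the scatter), whereas a 1.7-fold higher number from compound 1 to compound 4 (0.22 log units; within the scatter) leaves compound 4 within the scatter of the methoxy compound. No measurement here explains the shift. As far as these compounds go, whether an amine or a carboxylic acid in place of the acetamido group would give a similar number stays open.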